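Phenyl for ethoxy: the next step from compound 2

The source may hold more compounds than are shown below. What is called first, only, known or untested is meant among the compounds shown, and "the series" means these compounds.

Working notes on the series. For the measured compounds named here, compound 1 `COc1ccccc1N1CCN(CCCNc2nc(C)cc(C)c2C(N)=O)CC1` and compound 2 `CCOc1ccccc1N1CCN(CCCNc2ncccc2C(=O)N(C)C)CC1` are the two measured members. In a functional assay on aorta for antagonist activity at Alpha-1D adrenergic receptor (Rattus norvegicus) (on this read-out higher numbers stand for weaker binding and lower numbers for tighter binding), compound 2 gives 7.94 nM, the lowest of the two numbers; compound 1 gives 39.8 nM, a gap beyond the usual scatter. Compound 3 `CN(C)C(=O)c1cccnc1NCCCN1CCN(c2ccccc2-c2ccccc2)CC1` differs from compound 2 by phenyl in place of ethoxy on an aromatic carbon, on an aromatic carbon ortho to a large group. Going by the values given here, no measured pair shows a change of this kind, so the expectation rests on compound 2 alone. The expected step is a 2.5-fold higher number from compound 2 to compound 3 (0.40 log units; beyond the scatter), a modest move toward a higher number, possibly within the scatter. Compound 3 is estimated at 20 nM, with a range from 5 nM to 80 nM.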

Compound 3, dissociation constant: 63.1 nM
Beside the measured number, compound 3's estimate is 3.2-fold (0.50 log units) below it; low and high end bracket the measured number.
By their numbers in this assay, from the lowest: compound 2; then compounds 1 and 3 (each within the scatter of the next).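

In this assay, for the compounds shown here, the exchange of ethoxy for phenyl on this aromatic carbon ortho to a large group gives a 7.9-fold higher number from compound 2 to compound 3 (0.90 log units; beyond the scatter) and so provides the first measured change at this position. The position therefore does not accept this exchange without a loss in binding. The step replaces a group holding a hydrogen-bond acceptor with a larger one holding none, and this single pair cannot separate those two differences. Nothing measured here gives a cause for the step. On these data alone, whether propoxy or cyclohexyl at this place would stay close to compound 2 remains open.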